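Restoring an aryl group in place of furan on the core

A few compounds are considered here, and "the series" means these few. Any claim that something is new, unique, unknown or untested is made for them only; others in the source may bear on it.

Going by the values given here, the two measured members share a core in which a saturated ring carbon carries an aromatic substituent. Compound 1 `COc1ccc(C2CC(c3ccc4ccccc4c3)=NN2CC=O)cc1O` carries 3-hydroxy-4-methoxyphenyl there and, in a functional assay on PC-3 cells (Homo sapiens) for cytotoxicity, read by sulforhodamine B assay, with a stated time of 48 h (on this read-out lower numbers stand for stronger inhibition and higher numbers for weaker inhibition), compound 1 gives 2040 nM. Among the compounds with values here, compound 2 `O=CCN1N=C(c2ccc3ccccc3c2)CC1c1ccco1` carries furan-2-yl at the same position, and in this assay compound 2 gives 23000 nM, the highest of the two numbers; the single step available, an 11-fold higher number from compound 1 to compound 2 (1.05 log units; beyond the scatter), is large and beyond the scatter.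

Compound 3 `COc1ccc(C2CC(c3ccc4ccccc4c3)=NN2CC=O)cc1` is not yet measured. It differs from compound 2 in one place: 4-methoxyphenyl in place of furan-2-yl on a saturated ring carbon. Within the data shown here, the only step that bears on this change is the one from compound 1 to compound 2, where replacing a substituted phenyl by furan-2-yl raised the number greatly. Since compound 3 puts a methoxy-bearing phenyl back, but without the hydroxy of compound 1, a large step downward in this assay is expected, though perhaps not the full reverse of an 11-fold higher number from compound 1 to compound 2 (1.05 log units; beyond the scatter). Compound 3 is therefore estimated at 3500 nM, within 1200 nM to 12000 nM, which means an expected step of a 6.6-fold lower number from compound 2 to compound 3 (0.82 log units; beyond the scatter).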

Compound 3, half-maximal inhibitory concentration: 4530 nM
For compound 3 the middle estimate is 1.3-fold (0.11 log units) below the measured one; low and high end bracket the measured number.
By their numbers in this assay, from the lowest: compound 1; then compound 3; then compound 2.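

In this assay, 4-methoxyphenyl in place of furan-2-yl on the saturated ring carbon gives a 5.1-fold lower number from compound 2 to compound 3 (0.71 log units; beyond the scatter), so a six-membered aromatic ring of carbon bearing methoxy, even without the hydroxy, stands well apart from furan-2-yl at this position. Removing only the hydroxy gives a 2.2-fold higher number from compound 1 to compound 3 (0.35 log units; beyond the scatter), which splits the large gap seen earlier between compound 1 and compound 2: most of it goes with the exchange of furan-2-yl for 4-methoxyphenyl, and a smaller part, still beyond the scatter, goes with the hydroxy on the aromatic carbon. Nothing available on these compounds offers a reason for either step.

The compounds shown do not tell whether the methoxy itself contributes, since they include neither an unsubstituted phenyl nor a phenyl carrying hydroxy alone, and they do not show how an amine or a carboxylic acid on that phenyl would read. They also leave open whether the same order among the three groups would hold with a longer chain in place of the formylmethyl group on the core.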